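Nitrobenzylsulfanyl purine ribosides: swapping the cyclohexylamino for iodo

The compounds below may be only part of what the source reports. "The series", "measured", "known", "first", "only" and "open" are said of these compounds alone.

Measured so far in an assay on K562 cells for displacement of a labelled ligand from Equilibrative nucleoside transporter 1 (Homo sapiens), read by flow cytometry, with a stated time of 45 min; a higher number here means a weaker inhibitor, a lower number a stronger inhibitor:
- compound 1, `CCCCNc1nc(SCc2ccc([N+](=O)[O-])cc2)c2ncn([C@@H]3O[C@H](CO)[C@@H](O)[C@H]3O)c2n1`: 325 nM
- compound 2, `O=[N+]([O-])c1ccc(CSc2nc(NC3CCCCC3)nc3c2ncn3[C@@H]2O[C@H](CO)[C@@H](O)[C@H]2O)cc1`: 400 nM

Compound 2 holds the higher of the two numbers, with compound 1 the nearest neighbour; the step of a 1.2-fold higher number from compound 1 to compound 2 (0.09 log units; within the scatter) is within the scatter, so the two cannot be ordered against each other.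

Compound 3, `O=[N+]([O-])c1ccc(CSc2nc(I)nc3c2ncn3[C@@H]2O[C@H](CO)[C@@H](O)[C@H]2O)cc1`, is not yet measured. It differs from compound 2 in one place: iodo in place of cyclohexylamino on an aromatic carbon. For the measured compounds named here, the only measured step, from compound 1 to compound 2, exchanges one alkyl group on the ring nitrogen for another and leaves the amino group in place. It therefore says little about removing the cyclohexylamino altogether and putting a halogen on that aromatic carbon. Going by the values given here, no step here covers the loss of the hydrogen-bond donor and acceptor that the cyclohexylamino carries, so the direction is open. The expectation is a step of a 1.1-fold lower number from compound 2 to compound 3 (0.06 log units; within the scatter) that is not confidently beyond the scatter, with a wide range on either side. For compound 3 the estimate in this assay is 350 nM, with a range from 70 nM to 1800 nM.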

Compound 3, inhibition constant: 11 nM
The estimate for compound 3 lay 32-fold (1.50 log units) above the measured number; the measured number lies below the stated range.
By their numbers in this assay, from the lowest: compound 3; then compounds 1 and 2 (each within the scatter of the next).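

In this assay, iodo in place of cyclohexylamino gives a 36-fold lower number from compound 2 to compound 3 (1.56 log units; beyond the scatter) and iodo in place of butylamino gives a 30-fold lower number from compound 1 to compound 3 (1.47 log units; beyond the scatter), so this aromatic carbon between two ring nitrogen atoms responds strongly to what is attached directly to it, a sensitivity that a 1.2-fold higher number from compound 1 to compound 2 (0.09 log units; within the scatter) did not reveal when only the alkyl group on the nitrogen changed. Both large steps run the same way, so with the nitrobenzylsulfanyl group and the ribose unchanged, an amino nitrogen on this carbon is not needed for strong inhibition, and the loss of the hydrogen-bond donor and acceptor counted for cyclohexylamino comes with a lower number rather than a higher one. Nothing at hand explains the size of these steps.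

The compounds shown cannot separate the loss of the alkylamino group from the arrival of iodine, and a plain hydrogen on this carbon, or chloro or bromo there, would be the direct test of whether iodo itself matters. Going by these compounds, it also stays open whether a small amine such as methylamino or the unsubstituted amino group behaves like the two larger alkylamino groups.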